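A few compounds are considered here, and "the series" means these few. Any claim that something is new, unique, unknown or untested is made for them only; others in the source may bear on it.

In an ADME assay on Vero 76 cells (Chlorocebus sabaeus) for cytotoxicity, read by MTT assay, with a stated time of 96 h (a higher number here means that more compound is tolerated, a lower number that less compound is tolerated), compound 1 `NS(=O)(=O)c1ccc(N2N=C(c3ccccc3)CC2c2ccccc2Cl)cc1`, which carries a 2-chlorophenyl, gives 26000 nM. Compound 2 `NS(=O)(=O)c1ccc(N2N=C(c3ccc(OCc4ccccc4)cc3)CC2c2ccccc2)cc1` gives > 100000 nM, which is a limit of the assay and not a number. Compound 3 `NS(=O)(=O)c1ccc(N2N=C(c3ccc(OCc4ccccc4)cc3)CC2c2ccccc2Cl)cc1` differs from compound 2 in one place: chloro in place of hydrogen on an aromatic carbon, ortho to a large group. Since compound 1 with the same 2-chlorophenyl gives 26000 nM, a moderate fall in the tolerated concentration is expected in this assay. The expected change is an at least 2.0-fold lower number from compound 2 to compound 3 (0.30 log units; that floor lies within the scatter). For compound 3 the estimated value is 50000 nM, within a range of 18000 nM to 100000 nM.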

Compound 3, half-maximal cytotoxic concentration: 92000 nM
Compound 3: the middle estimate sits 1.8-fold (0.26 log units) below what was measured, and the stated range covers the measured number.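

Chloro in place of hydrogen, ortho to a large group, gives an at least 1.0-fold lower number from compound 2 to compound 3 (0.03 log units; that floor lies within the scatter) in this assay, so this change shows no fall beyond the scatter. Compound 2 stands at a limit of the assay and not at a number, so that step is only a floor: the limit of > 100000 nM in this assay, at which 1 of the 3 values shown sits. With the 2-chlorophenyl kept, benzyloxy in place of hydrogen gives a 3.5-fold higher number from compound 1 to compound 3 (0.55 log units; beyond the scatter), so the 2-chlorophenyl alone does not set the tolerated concentration.

Going by these compounds, the true size of the chloro step stays open. So does whether fluoro or methoxy at the same place would behave like chloro.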